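Methoxy to Hydroxy on a Pyrazole Urea Scaffold

The source may report more compounds than this note shows. Statements on the series, on what has been measured and on what is new or still open speak of the compounds shown alone.

Compound 1 `O=C(Nc1cccc(-n2cc(-c3ccncc3)c(-c3ccc(Cl)c(O)c3)n2)c1)Nc1cccc(C(F)(F)F)c1`: 12600 nM
Compound 2 `O=C(Nc1cccc(-n2cc(-c3ccncc3)c(-c3ccc(Cl)c(O)c3)n2)c1)Nc1ccc(Cl)c(Cl)c1`: 6050 nM
Compound 3 `COc1cc(-c2nn(-c3cccc(NC(=O)Nc4ccc(Cl)c(C(F)(F)F)c4)c3)cc2-c2ccncc2)ccc1Cl`: 1690 nM

Of the compounds shown here, three have been measured in a functional assay on MDA-MB-435 cells (Homo sapiens) for inhibition, read by sulforhodamine B assay, with a stated time of 48 h; a higher number here means a weaker inhibitor of growth, a lower number a stronger inhibitor of growth. Compound 3 stands lowest of the three, with compound 2 the nearest and compound 1 the furthest. Compound 1 and compound 2 share the hydroxy-bearing ring and differ only in the aryl group on the urea; that step, a 2.1-fold lower number from compound 1 to compound 2 (0.32 log units; beyond the scatter), is modest but beyond the scatter.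

Compound 4 `O=C(Nc1cccc(-n2cc(-c3ccncc3)c(-c3ccc(Cl)c(O)c3)n2)c1)Nc1ccc(Cl)c(C(F)(F)F)c1` has not yet been measured. It differs from compound 3 by hydrogen in place of methyl on an oxygen on an aromatic ring, that is, methoxy to hydroxy, giving 4-chloro-3-hydroxyphenyl in place of 4-chloro-3-methoxyphenyl, while keeping the urea aryl of compound 3.

Going by the values given here, no measured pair isolates this change. Compound 1 and compound 2, both hydroxy analogues, give weaker numbers than compound 3, but each also carries a different urea aryl, so their values cannot be read as the methoxy-to-hydroxy effect alone. The urea step between compound 1 and compound 2 shows that the aryl alone moves the number modestly.

Compound 4 is therefore expected to land somewhat above compound 3, with the step of a 1.8-fold higher number from compound 3 to compound 4 (0.25 log units; within the scatter) uncertain in size. The estimate for compound 4 is 3000 nM, within 1000 nM to 10000 nM.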

Compound 4, concentration for total growth inhibition: 1770 nM
Compound 4: the middle estimate sits 1.7-fold (0.23 log units) above what was measured; the measured number falls inside the stated range.
By their numbers in this assay, from the lowest: compounds 3 and 4 (each within the scatter of the next); then compound 2; then compound 1.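

In this assay, the change from methoxy to hydroxy on this aromatic oxygen leaves no readable step (a 1.0-fold higher number from compound 3 to compound 4 (0.02 log units; within the scatter)), so the methyl can go from this position without a measurable difference between these two compounds. With the hydroxy group held constant, the urea aryl alone moves the number beyond the scatter, both for trifluoromethyl in place of chloro on an aromatic carbon (a 3.4-fold lower number from compound 2 to compound 4 (0.53 log units; beyond the scatter)) and for chloro in place of hydrogen on an aromatic carbon (a 7.1-fold lower number from compound 1 to compound 4 (0.85 log units; beyond the scatter)). The high numbers of the two earlier hydroxy compounds therefore go with their urea aryl groups rather than with the hydroxy group, although nothing at hand gives a reason for either the flat step or the urea steps.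

From the compounds shown here alone, whether methoxy and hydroxy also match when the urea carries 3,4-dichlorophenyl or 3-(trifluoromethyl)phenyl remains open. Going by these compounds, it is equally open how this assay would respond to an amine, an ethoxy group or a longer chain at this place on the ring.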